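This account rests on a few compounds, and the source may have more. Where it says the series, first, only, none or still open, it means among the compounds named here.

Three compounds sharing one core and differing in the aryl group on the amide nitrogen have been measured in a functional assay on A549 cells (Homo sapiens) for cytotoxicity, read by MTT assay, with a stated time of 72 h; on this read-out higher numbers stand for weaker inhibition and lower numbers for stronger inhibition. Compound 3 (`O=C(CN1CCN(c2nnc(Cc3ccncc3)c3ccccc23)CC1)Nc1ccc(F)c(C(F)(F)F)c1`), at 16000 nM, lies in the middle of this short series. Compound 1 (`Cc1ccc(NC(=O)CN2CCN(c3nnc(Cc4ccncc4)c4ccccc34)CC2)c(C)c1`) gives 45000 nM, and compound 2 (`O=C(CN1CCN(c2nnc(Cc3ccncc3)c3ccccc23)CC1)Nc1cccc(F)c1`) gives 4600 nM. Compound 4 (`O=C(CN1CCN(c2nnc(Cc3ccncc3)c3ccccc23)CC1)Nc1ccc(F)c(Cl)c1`) is the next to be read. It turns 4-fluoro-3-(trifluoromethyl)phenyl into 3-chloro-4-fluorophenyl, with chloro in place of trifluoromethyl on an aromatic carbon, ortho to a fluoro group and meta to a large group (chloro in place of trifluoromethyl on an aromatic carbon).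

Among the measured compounds shown here, no measured step makes this exact exchange, so the evidence is indirect. Changes to this aryl group have so far given modest steps: a 9.8-fold lower number from compound 1 to compound 2 (0.99 log units; beyond the scatter), a 2.8-fold lower number from compound 1 to compound 3 (0.45 log units; beyond the scatter) and a 3.5-fold higher number from compound 2 to compound 3 (0.54 log units; beyond the scatter). The last bears most closely, since it shows that the aryl group of compound 3 carries a higher number than that of compound 2. Compound 4 loses the trifluoromethyl group and keeps only a single heavy atom in its place, so it is expected to move part of the way back towards compound 2. The expected step is modest and towards lower numbers, lying just beyond the scatter: a 2.1-fold lower number from compound 3 to compound 4 (0.33 log units; beyond the scatter). For compound 4 the estimated value is 7500 nM, with an expected range of 2500 nM to 22000 nM.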

Compound 4, half-maximal inhibitory concentration: 12300 nM
Estimate against measurement, compound 4: 1.6-fold (0.21 log units) below, and the stated range covers the measured number.
By their numbers in this assay, from the lowest: compound 2; then compounds 4 and 3 (each within the scatter of the next); then compound 1.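

In this assay, chloro in place of trifluoromethyl on an aromatic carbon, ortho to a fluoro group, gives a 1.3-fold lower number from compound 3 to compound 4 (0.11 log units; within the scatter), so at this place the count of heavy atoms can drop from 4 to 1 with no change that can be told from the scatter. The 3-chloro-4-fluorophenyl group also stays apart from the 3-fluorophenyl group, with a 2.7-fold higher number from compound 2 to compound 4 (0.43 log units; beyond the scatter), and from the 2,4-dimethylphenyl group, with a 3.7-fold lower number from compound 1 to compound 4 (0.56 log units; beyond the scatter), so the gap to compound 2 that compound 3 first showed remains with chloro on this carbon. No measurement is at hand that would explain these readings.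

It remains open whether that gap to compound 2 goes with the fluoro group shared by compound 3 and compound 4 or with the group on the neighbouring carbon, since among the compounds shown neither chloro nor trifluoromethyl appears without that fluoro group. On these data alone, it is also open how an amine, a carboxylic acid or a longer chain on this aromatic carbon would read.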